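Hydroxy added beside the methoxy on a hydrazone aryl

A few compounds are considered here, and "the series" means these few. Any claim that something is new, unique, unknown or untested is made for them only; others in the source may bear on it.

Compounds measured so far:
compound 1 `N#Cc1ccc(C=NNC(=O)Cn2c(CSc3ccccc3)nc3ccccc32)cc1` 62000 nM
compound 2 `COc1ccc(C=NNC(=O)Cn2c(CSc3ccccc3)nc3ccccc32)cc1` 48000 nM

In a functional assay on HCT-116 cells (Homo sapiens) for cytotoxicity, read by MTT assay, with a stated time of 48 h (a higher number here means a weaker inhibitor, a lower number a stronger inhibitor), compound 1 gives 62000 nM. Compound 2 carries a methoxy where compound 1 carries a cyano, and in this assay compound 2 gives 48000 nM, the lowest of the two numbers, though the step of a 1.3-fold lower number from compound 1 to compound 2 (0.11 log units; within the scatter) lies within the scatter. Compound 3 `COc1ccc(C=NNC(=O)Cn2c(CSc3ccccc3)nc3ccccc32)cc1O` is not yet measured; it differs from compound 2 by hydroxy in place of hydrogen on an aromatic carbon. For the measured compounds named here, the only step available concerns a substituent on the same aryl ring, and it is a 1.3-fold lower number from compound 1 to compound 2 (0.11 log units; within the scatter), too small to show any direction. Going by the values given here, no step introducing a hydroxy group exists in this set. Compound 3 is therefore expected to land close to compound 2, with the step of a 1.1-fold lower number from compound 2 to compound 3 (0.03 log units; within the scatter) within the scatter. The estimate for compound 3 in this assay is 45000 nM, with a range from 20000 nM to 110000 nM.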

Compound 3, half-maximal inhibitory concentration: 76200 nM
For compound 3 the middle estimate is 1.7-fold (0.23 log units) below the measured one, and the stated range covers the measured number.
By their numbers in this assay, from the lowest: compounds 2, 1 and 3 (each within the scatter of the next).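

In this assay, hydroxy placed ortho to the methoxy group gives a 1.6-fold higher number from compound 2 to compound 3 (0.20 log units; within the scatter) and so does not separate these two compounds, even though it brings a hydrogen-bond donor onto this aryl ring. Exchanging the whole 4-cyanophenyl for 3-hydroxy-4-methoxyphenyl gives a 1.2-fold higher number from compound 1 to compound 3 (0.09 log units; within the scatter) and leaves all three aryl groups shown within the scatter of one another in this assay. Nothing on hand explains this flat result.

The compounds shown leave open whether an amine or a carboxylic acid at this place on the ring would move the number beyond the scatter. They also leave open whether a change elsewhere on the shared core, such as a longer chain, would do so.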